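The compounds below may be only part of what the source reports. "The series", "measured", "known", "first", "only" and "open" are said of these compounds alone.

Compound 1 `NS(=O)(=O)NCC1CCN(c2cc(-c3ccccc3)ncn2)CC1` gives 34300 nM in a functional assay on MCF7 cells (Homo sapiens) for antiproliferative activity, read by sulforhodamine B assay, with a stated time of 48 h; a lower number here means a stronger inhibitor of growth, a higher number a weaker inhibitor of growth.
Compound 2 `NS(=O)(=O)NCC1CCN(c2cc(-c3ccc(C(F)(F)F)cc3)ncn2)CC1` gives 22500 nM in this assay.

On the numbers shown, compound 2 stands at the lower of the two, yet the step of a 1.5-fold lower number from compound 1 to compound 2 (0.18 log units; within the scatter) lies within the scatter, so nothing separates them. Compound 3 `COC(=O)c1ccc(-c2cc(N3CCC(CNS(N)(=O)=O)CC3)ncn2)cc1` differs from compound 2 by methoxycarbonyl in place of trifluoromethyl on an aromatic carbon. Within the data shown here, the only measured step touching this aromatic carbon, a 1.5-fold lower number from compound 1 to compound 2 (0.18 log units; within the scatter), stayed within the scatter, so for compound 3 no step beyond the scatter is expected in this assay. Compound 3 is therefore estimated at 22000 nM in this assay, between 8000 nM and 60000 nM. This estimate means an expected step of a 1.0-fold lower number from compound 2 to compound 3 (0.01 log units; within the scatter).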

Compound 3, concentration for 50% growth inhibition: 17700 nM
The estimate for compound 3 lay 1.2-fold (0.09 log units) above the measured number; low and high end bracket the measured number.
By their numbers in this assay, from the lowest: compounds 3, 2 and 1 (each within the scatter of the next).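

Methoxycarbonyl brings hydrogen-bond acceptors that trifluoromethyl lacks, yet in this assay the swap gives only a 1.3-fold lower number from compound 2 to compound 3 (0.10 log units; within the scatter) and the comparison with hydrogen gives a 1.9-fold lower number from compound 1 to compound 3 (0.29 log units; within the scatter) as its step. So two quite different groups at this aromatic carbon, para to a large group, both remain within the scatter of hydrogen. No evidence explains this result.

Going by these compounds, whether an amine or a carboxylic acid here would give a step beyond the scatter stays open. So does whether changes elsewhere on the shared core would count for more.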